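The source may report more compounds than this note shows. Statements on the series, on what has been measured and on what is new or still open speak of the compounds shown alone.

Measured compounds: compound 1 `Fc1ccc([C@@H]2NCCOC23COC[C@H](c2ccccc2)C3)cc1` with 99 nM; compound 2 `COc1ccc(C(C)C)cc1[C@H]1COCC2(C1)OCCN[C@H]2c1ccc(F)cc1` with 2.8 nM; compound 3 `COc1ccc(OC)c([C@H]2COCC3(C2)OCCN[C@H]3c2ccc(F)cc2)c1` with 16 nM.

In an assay on CHO cells for displacement of a labelled ligand from Substance-P receptor (Homo sapiens) (on this read-out lower numbers stand for stronger inhibition and higher numbers for weaker inhibition), compound 3 stands second highest of the three; compound 2 sits lower, while compound 1, which lacks both substituents on that ring, gives 99 nM. Compound 4 `COc1ccccc1[C@H]1COCC2(C1)OCCN[C@H]2c1ccc(F)cc1` differs from compound 3 by hydrogen in place of methoxy on an aromatic carbon. Among the measured compounds shown here, the only measured step at that place is a 5.7-fold higher number from compound 2 to compound 3 (0.76 log units; beyond the scatter), where an isopropyl was swapped for methoxy; removing the group entirely is a larger change, and the values of compound 1 and compound 3 suggest that bare positions on this ring go with weaker binding. A modest rise in the number is therefore expected, a 2.5-fold higher number from compound 3 to compound 4 (0.40 log units; beyond the scatter). Compound 4 is estimated at 40 nM, within 12 nM to 150 nM.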

Compound 4, half-maximal inhibitory concentration: 13 nM
Beside the measured number, compound 4's estimate is 3.1-fold (0.49 log units) above it, and the stated range covers the measured number.
By their numbers in this assay, from the lowest: compound 2; then compounds 4 and 3 (each within the scatter of the next); then compound 1.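

At the ring position para to a methoxy group, losing the methoxy changes little in this assay, with a 1.2-fold lower number from compound 3 to compound 4 (0.09 log units; within the scatter). An isopropyl at that place does not behave the same way, since a 4.6-fold higher number from compound 2 to compound 4 (0.67 log units; beyond the scatter), so here the isopropyl gives a result that neither hydrogen nor methoxy gives. The methoxy that remains on the ring goes with a lower number than the bare ring, with a 7.6-fold lower number from compound 1 to compound 4 (0.88 log units; beyond the scatter). Nothing available explains these differences. From the compounds shown here alone, whether a chlorine, a tert-butyl or an amine at this position would match the isopropyl stays open.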